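A few compounds are considered here, and "the series" means these few. Any claim that something is new, unique, unknown or untested is made for them only; others in the source may bear on it.

Measured so far in an assay on H4 cells for inhibition of Fatty-acid amide hydrolase 1 (Homo sapiens); a lower number here means a stronger inhibitor, a higher number a weaker inhibitor:
compound 1, `CCOC(=O)CCCOc1ccc(-n2cnc(-c3ccccc3)c2-c2ccccc2)cc1`: 64 nM
compound 2, `COC(=O)COc1cccc(-n2cnc(-c3ccccc3)c2-c2ccccc2)c1`: 6500 nM
compound 3, `CCOC(=O)CC(CC)CCCCCn1c(C)nc(-c2ccccc2)c1-c1ccccc1`: 9900 nM

Compound 3 carries the highest of the three numbers. Its nearest neighbour is compound 2, whose value lies within the scatter of that of compound 3; compound 1 sits far lower, beyond the scatter.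

Compound 4, `CNC(=O)NCCCCCCn1c(C)nc(-c2ccccc2)c1-c1ccccc1`, is the next step from compound 3. The change is ((methylcarbamoyl)amino)methyl in place of 1-((ethoxycarbonyl)methyl)propyl on a saturated chain carbon, five bonds along the chain from an aromatic nitrogen. Going by the values given here, no step between measured compounds informs this change, so the direction is open. The step from compound 3 to compound 4 is expected to be a 1.7-fold lower number from compound 3 to compound 4 (0.22 log units; within the scatter), that is, no movement beyond the scatter is expected. For compound 4 in this assay the estimate is 6000 nM, with a range from 1200 nM to 30000 nM.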

Compound 4, half-maximal inhibitory concentration: > 10000 nM
Compound 4 gave a limit, no number; the forecaster's own chance of this, stated with the estimate: 20%; at least 1.6-fold (0.22 log units) between middle value and limit.
By their numbers in this assay, from the lowest: compound 1; then compounds 2 and 3 (each within the scatter of the next). At a limit, above all of these: compound 4.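

In this assay, ((methylcarbamoyl)amino)methyl in place of 1-((ethoxycarbonyl)methyl)propyl on a saturated chain carbon, five bonds along the chain from an aromatic nitrogen, gives a number no lower from compound 3 to compound 4 (the limit leaves the size open). Compound 4 gives > 10000 nM, which is a limit and not a number. Exchanging the ester-bearing group for this group with two hydrogen-bond donors therefore brings no lower number at this position.

How far the number rises cannot be read from the limit. On these data alone, whether a carboxylic acid or an amine at this chain end would give a lower number remains open.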